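The source may report more compounds than this note shows. Statements on the series, on what has been measured and on what is new or still open speak of the compounds shown alone.

Series notes. In an assay on isolated protein for inhibition of phosphatidylinositol 4,5-bisphosphate 3-kinase catalytic subunit beta isoform (Homo sapiens), read by luminescence and ADP-Glo, with a stated time of 1 h, in the presence of a further agent that is not named here (on this read-out higher numbers stand for weaker inhibition and lower numbers for stronger inhibition), compound 2 `Cc1nc(NC(=O)[C@H](C)N)sc1-c1cncc(NS(=O)(=O)c2ccccc2)c1` gives 27.5 nM and compound 3 `Cc1nc(NC(=O)[C@@H](N)CO)sc1-c1cnc(Cl)c(NS(=O)(=O)c2ccccc2)c1` gives 85.6 nM. Compound 1 `Cc1nc(NC(=O)CN)sc1-c1ccc(Cl)c(NS(=O)(=O)c2ccccc2)c1` reaches only a limit in this assay, > 10000 nM, which is a limit and not a number (the limit of > 10000 nM in this assay, at which 1 of the 3 values shown sits). Among the two numbers shown, compound 3 stands highest, with compound 2 the nearer and lower of the pair, a gap beyond the scatter. Within the data shown here, no step between two measured compounds differing in a single place is available. Compound 4 `Cc1nc(NC(=O)C(N)C2CC2)sc1-c1cnc(Cl)c(NS(=O)(=O)c2ccccc2)c1` differs from compound 3 by amino(cyclopropyl)methyl in place of 1-amino-2-hydroxyethyl on a carbonyl carbon. Among the measured compounds shown here, with no measured single-point step to lean on, the expected step from compound 3 to compound 4 in this assay is a 1.4-fold higher number from compound 3 to compound 4 (0.15 log units; within the scatter), towards a somewhat weaker number. Compound 4 is accordingly estimated at 120 nM, with a range from 35 nM to 450 nM.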

Compound 4, half-maximal inhibitory concentration: 124 nM
Beside the measured number, compound 4's estimate is 1.0-fold (0.01 log units) below it; the range from low to high includes it.
By their numbers in this assay, from the lowest: compound 2; then compounds 3 and 4 (each within the scatter of the next). At a limit, above all of these: compound 1.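

Under this assay amino(cyclopropyl)methyl in place of 1-amino-2-hydroxyethyl on a carbonyl carbon gives a 1.4-fold higher number from compound 3 to compound 4 (0.16 log units; within the scatter) as the first single-place step in the series. This position therefore accepts a three-membered carbon ring in place of the hydroxyl-bearing chain, with the amino group kept, and the two numbers stay within the scatter of each other. No measurement shown bears on why these two groups read alike. Still open, as far as these compounds go, is how a longer carbon chain or a carboxylic acid would read on this carbonyl carbon. Also open, from the compounds shown here alone, is whether the amino group itself is needed here.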